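This account rests on a few compounds, and the source may have more. Where it says the series, first, only, none or still open, it means among the compounds named here.

Compound 1 `COc1ncc(-c2ccc3nc(NC(=O)N4CCCC4)nn3c2)cc1NS(=O)(=O)c1ccc(F)cc1` gives 1290 nM in a functional assay on HCT-116 cells (Homo sapiens) for cytotoxicity, read by MTT assay, with a stated time of 72 h; on this read-out higher numbers stand for weaker inhibition and lower numbers for stronger inhibition. Among the compounds with values here, compound 2 `COc1ncc(-c2ccc3nc(NC(=O)NC4CC4)nn3c2)cc1NS(=O)(=O)c1ccc(F)cc1` gives 90 nM in this assay, the lowest of the two numbers so far, and the step of a 14-fold lower number from compound 1 to compound 2 (1.16 log units; beyond the scatter) lies well beyond the scatter. Compound 3 `COc1ncc(-c2ccc3nc(NC(=O)NCC(=O)N4CCOCC4)nn3c2)cc1NS(=O)(=O)c1ccc(F)cc1` differs from compound 2 by ((morpholin-4-yl)carbonyl)methyl in place of cyclopropyl on an amide-type nitrogen. Within the data shown here, only that single step is known, and it concerns the group on the carbonyl carbon rather than this amide-type nitrogen, so it offers little direct guidance; a move to a higher number is expected, written as a 2.8-fold higher number from compound 2 to compound 3 (0.44 log units; beyond the scatter). Compound 3 is estimated at 250 nM, within 70 nM to 900 nM.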

Compound 3, half-maximal inhibitory concentration: 490 nM
For compound 3 the middle estimate is 2.0-fold (0.29 log units) below the measured one, within the range that was stated.
By their numbers in this assay, from the lowest: compound 2; then compound 3; then compound 1.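

On the amide-type nitrogen in this assay, ((morpholin-4-yl)carbonyl)methyl falls short of cyclopropyl, with a 5.4-fold higher number from compound 2 to compound 3 (0.74 log units; beyond the scatter), yet it still beats pyrrolidin-1-yl on the carbonyl carbon, with a 2.6-fold lower number from compound 1 to compound 3 (0.42 log units; beyond the scatter). Both compounds that keep the amide hydrogen, compound 2 and compound 3, therefore give lower numbers than compound 1. No available evidence accounts for these differences.

On these data alone, whether the morpholin-4-yl part or the carbonyl part drives the rise from cyclopropyl remains open. A cyclobutyl group, a plain ethyl chain or a carboxylic acid on the same nitrogen would help separate these.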